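Hydroxy for methoxy on the urea of compound 3

The source may report more compounds than this note shows. Statements on the series, on what has been measured and on what is new or still open speak of the compounds shown alone.

In a functional assay on PC-3 cells (Homo sapiens) for inhibition, read by sulforhodamine B assay, with a stated time of 48 h (a higher number here means that more compound is tolerated, a lower number that less compound is tolerated), compound 3 `COc1cc(-c2nn(-c3cccc(NC(=O)Nc4ccc(Cl)c(Cl)c4)c3)cc2-c2ccncc2)ccc1Cl` reports only the limit > 50000 nM and no number. Compound 2 `COc1cc(-c2nn(-c3cccc(NC(=O)c4cccc(C(F)(F)F)c4)c3)cc2-c2ccncc2)ccc1Cl` likewise ends at the limit > 50000 nM. The step that the two limits leave unreadable from compound 2 to compound 3 therefore stays unreadable. Compound 1 `O=C(Nc1cccc(-n2cc(-c3ccncc3)c(-c3ccc(Cl)c(O)c3)n2)c1)Nc1cccc(C(F)(F)F)c1` also ends at a limit, > 32500 nM. Going by the values given here, two of the three values sit at the limit of > 50000 nM in this assay, at which 2 of the 3 values shown sit, and the remaining one at the limit of > 32500 nM in this assay, at which 1 of the 3 values shown sits, so no measured step has a readable size. Compound 4 `O=C(Nc1cccc(-n2cc(-c3ccncc3)c(-c3ccc(Cl)c(O)c3)n2)c1)Nc1ccc(Cl)c(Cl)c1` differs from compound 3 by hydrogen in place of methyl on an oxygen on an aromatic ring. Compound 1 carries the same hydroxy group on the same urea and stays at a limit, so no change beyond the scatter is expected, and the step from compound 3 to compound 4 is estimated as a step that the limit leaves unreadable from compound 3 to compound 4. Compound 4 is expected at 60000 nM, with a range from 20000 nM to 200000 nM, most likely again as a limit.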

Compound 4, concentration lethal to 50% of the cells: > 32500 nM
Compound 4: no number, only a limit (the forecaster's own chance of this, stated with the estimate: 85%); the middle value does not contradict the limit.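

In this assay compound 4 gives only the limit > 32500 nM. Compound 1 and compound 3 also end at limits, so neither step to compound 4 can be read. The compounds shown leave open whether any member of this series reaches a measurable value.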